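The source may report more compounds than this note shows. Statements on the series, on what has been measured and on what is new or still open speak of the compounds shown alone.

Compound 3 `Cn1c(-c2ccc(N)cc2)nc2cc(C(F)(F)F)ccc21` carries an amino group on the phenyl ring joined to the shared core. Going by the values given here, in an ADME assay on BHK cells (Mesocricetus auratus) for cytotoxicity, read by MTT assay, with a stated time of 96 h (a higher number here means that more compound is tolerated, a lower number that less compound is tolerated), compound 3 gives 85000 nM, the only plain number among the three compounds measured so far. Compound 1 `Cn1c(-c2ccc([N+](=O)[O-])cc2)nc2cc(C(F)(F)F)ccc21`, with nitro in place of that amino group, reaches only a limit in this assay, where compound 1 gives > 100000 nM. Compound 2 `CC(=O)Nc1ccc(-c2nc3cc(C(F)(F)F)ccc3n2C)cc1`, which bears acetamido, likewise reaches only a limit in this assay, where compound 2 gives > 100000 nM. Because of the limit of > 100000 nM in this assay, at which 2 of the 3 values shown sit, the steps ending at compound 3 are not fully readable: an at least 1.1-fold lower number from compound 1 to compound 3 (0.07 log units; that floor lies within the scatter) and an at least 1.1-fold lower number from compound 2 to compound 3 (0.07 log units; that floor lies within the scatter) each give only a floor that lies within the scatter, and a step that the two limits leave unreadable from compound 1 to compound 2 cannot be read at all.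

Compound 4 `CCC(=O)Nc1ccc(-c2nc3cc(C(F)(F)F)ccc3n2C)cc1` differs from compound 3 by propanoyl in place of hydrogen on a nitrogen on an aromatic ring. This is the reverse kind of change to the one seen in an at least 1.1-fold lower number from compound 2 to compound 3 (0.07 log units; that floor lies within the scatter), so in this assay a step of about a 1.2-fold higher number from compound 3 to compound 4 (0.07 log units; within the scatter) is expected, no larger than the scatter and possibly ending at the limit of the assay. Compound 4 is therefore estimated at 100000 nM, with a range from 50000 nM to 200000 nM.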

Compound 4, half-maximal cytotoxic concentration: > 100000 nM
Compound 4: no number, only a limit; the forecaster's own chance of this, stated with the estimate: 50%; the middle value sits exactly at the limit.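

On this nitrogen, propanoyl gives the same kind of result in this assay as acetyl: compound 4, like compound 2, reaches only a limit and gives no plain number. Going by these compounds alone, the one partly readable step is an at least 1.1-fold higher number from compound 3 to compound 4 (0.07 log units; that floor lies within the scatter) and it gives only a floor, so adding propanoyl to the amino group of compound 3 has no effect of readable size here. The steps from compound 1 and compound 2 to compound 4 cannot be read because both ends of each step sit at the same limit: the limit of > 100000 nM in this assay, at which 3 of the 4 values shown sit.

Going by these compounds, how far the tolerated concentration lies beyond that limit for either amide remains open. Also open, on these data alone, is whether a longer chain such as butanoyl, or a carboxylic acid in place of the amino group, would give a plain number in this assay at all.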